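The source may report more compounds than this note shows. Statements on the series, on what has been measured and on what is new or still open speak of the compounds shown alone.

Values in a functional assay on Raji cells (Homo sapiens) for antiproliferative activity, read by MTT assay, with a stated time of 48 h; on this read-out lower numbers stand for stronger inhibition and higher numbers for weaker inhibition:

- compound 1 `CN(C)CCCn1c(N)c(-c2nc3ccccc3[nH]2)c2nc(C#N)c(C#N)nc21`: 1230 nM
- compound 2 `CN1CCN(CCCn2c(N)c(-c3nc4ccccc4[nH]3)c3nc(C#N)c(C#N)nc32)CC1`: 2620 nM
- compound 3 `CCCCn1c(N)c(-c2nc3ccccc3[nH]2)c2nc(C#N)c(C#N)nc21`: > 50000 nM, a limit and not a number

Compound 3 has no number, only a limit: the limit of > 50000 nM in this assay, at which 1 of the 3 values shown sits.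

The next change leads to compound 4 `N#Cc1nc2c(-c3nc4ccccc4[nH]3)c(N)n(CCCN3CCCCC3)c2nc1C#N`, with piperidin-1-yl in place of methyl on a saturated chain carbon, three bonds along the chain from an aromatic nitrogen.

Two measured steps make the reverse kind of change at the same place, with methyl entering: an at least 40-fold higher number from compound 1 to compound 3 (1.60 log units; beyond the scatter) and an at least 19-fold higher number from compound 2 to compound 3 (1.28 log units; beyond the scatter). Both are large. Exchanging one amino group for the other mattered far less: a 2.1-fold higher number from compound 1 to compound 2 (0.33 log units; beyond the scatter).

A large step to lower numbers is therefore expected in this assay. The expected step is an at least 25-fold lower number from compound 3 to compound 4 (1.39 log units; beyond the scatter). For compound 4 the estimated value is 2000 nM, with an expected range of 700 nM to 6000 nM.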

Compound 4, half-maximal inhibitory concentration: 3380 nM
The estimate for compound 4 lay 1.7-fold (0.23 log units) below the measured number; the range from low to high includes it.
By their numbers in this assay, from the lowest: compound 1; then compounds 2 and 4 (each within the scatter of the next). At a limit, above all of these: compound 3.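

Compound 3 stands at a limit and not a number. In this assay, a ring amine with no further substituent also restores activity at this chain end, with an at least 14-fold lower number from compound 3 to compound 4 (1.17 log units; beyond the scatter). Among the amines, the exchange for piperidin-1-yl gives a 1.3-fold higher number from compound 2 to compound 4 (0.11 log units; within the scatter) and a 2.7-fold higher number from compound 1 to compound 4 (0.44 log units; beyond the scatter), so the two ring amines do not separate, while dimethylamino keeps a modest edge over piperidin-1-yl.

Still open, from the compounds shown here alone, is whether the chain end needs an amine at all, which a morpholine or a hydroxyl there would test. Going by these compounds, the effect of a shorter or longer chain carrying dimethylamino also remains unknown.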